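A Second Chloro Group on the Core of Compound 1

The source may hold more compounds than are shown below. What is called first, only, known or untested is meant among the compounds shown, and "the series" means these compounds.

Measured compounds:
- compound 1 `ClCc1ccccc1Cn1cnc2ncnc(Cl)c21`: 7940 nM
- compound 2 `Nc1nc(Cl)c2ncn(Cc3cccc(CCl)c3)c2n1`: 42700 nM

In a functional assay on NCI-H226 cells (Homo sapiens) for cytotoxicity, read by sulforhodamine B assay, with a stated time of 48 h (on this read-out lower numbers stand for stronger inhibition of growth and higher numbers for weaker inhibition of growth), compound 1 gives 7940 nM, the lowest of the two numbers shown. Compound 2 gives 42700 nM in this assay, a higher number that lies beyond the usual scatter. Among the measured compounds shown here, the two measured compounds differ in more than one place, so no single measured step shows what one change alone does.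

Compound 3 `ClCc1ccccc1Cn1cnc2nc(Cl)nc(Cl)c21` is not yet measured. It differs from compound 1 by chloro in place of hydrogen on an aromatic carbon. For the measured compounds named here, with no measured step of this kind to lean on, the expectation rests on compound 1 alone, whose value 7940 nM is the starting point. The expected step of a 1.3-fold lower number from compound 1 to compound 3 (0.12 log units; within the scatter) is small and within the scatter, in either direction. For compound 3 the estimated value in this assay is 6000 nM, with a range from 2000 nM to 20000 nM.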

Compound 3, concentration for total growth inhibition: 6760 nM
Compound 3: the middle estimate sits 1.1-fold (0.05 log units) below what was measured; low and high end bracket the measured number.
By their numbers in this assay, from the lowest: compounds 3 and 1 (each within the scatter of the next); then compound 2.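

Among the compounds shown here, compound 3 adds the first comparison here in which only one thing changes: in this assay, placing chloro in place of hydrogen on an aromatic carbon, between two ring nitrogen atoms, gives a 1.2-fold lower number from compound 1 to compound 3 (0.07 log units; within the scatter). This position therefore accepts a chloro group without a change in growth inhibition that can be told apart from ordinary variation between repeated measurements. No outside measurement is available to explain why the number stays put.

Going by these compounds, whether a larger or very different group, such as a methoxy group or a carboxylic acid, would also leave the number unchanged in this place remains open. This single step also cannot show whether chloro would behave the same way if the rest of the molecule were different.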